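Cytotoxicity notes on two limit values and a carbamoyl variant

This account rests on a few compounds, and the source may have more. Where it says the series, first, only, none or still open, it means among the compounds named here.

Compound 1 `COc1cc(-c2nn(-c3cccc(NC(=O)c4cccc(C(F)(F)F)c4)c3)cc2-c2ccncc2)ccc1Cl` carries a 3-(trifluoromethyl)phenyl on a carbonyl carbon whose other neighbour is an amide-type nitrogen. In a functional assay on OVCAR-4 cells (Homo sapiens) for inhibition, read by sulforhodamine B assay, with a stated time of 48 h (a higher number here means that more compound is tolerated, a lower number that less compound is tolerated), compound 1 gives > 50000 nM, which is a limit of the assay and not a number, namely (the limit of > 50000 nM in this assay, at which 1 of the 2 values shown sits). Compound 2 `O=C(Nc1cccc(-n2cc(-c3ccncc3)c(-c3ccc(Cl)c(O)c3)n2)c1)Nc1ccc(Cl)c(C(F)(F)F)c1` is the other measured member of the set. In this assay compound 2 gives > 32500 nM, again only a limit, (the limit of > 32500 nM in this assay, at which 1 of the 2 values shown sits). Within the data shown here, no step between the two can be computed, and compound 1 stands on a limit only, with no number of its own to rank.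

Compound 3 `COc1cc(-c2nn(-c3cccc(NC(=O)Nc4ccc(Cl)c(Cl)c4)c3)cc2-c2ccncc2)ccc1Cl` is not yet measured. It differs from compound 1 in one place: (3,4-dichlorophenyl)amino in place of 3-(trifluoromethyl)phenyl on a carbonyl carbon. Compound 2 already carries a carbamoyl of this kind and still gives > 32500 nM in this assay, so no change beyond the scatter is expected. The estimated step is a number no higher from compound 1 to compound 3 (the limit leaves the size open), that is, none. Compound 3 is expected to give 50000 nM in this assay, within 20000 nM to 100000 nM, most probably reported as a limit once more.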

Compound 3, concentration lethal to 50% of the cells: > 50000 nM
Compound 3: no number, only a limit; the forecaster's own chance of this, stated with the estimate: 80%; the middle value lies on the limit itself.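

In this assay compound 3 gives > 50000 nM, a limit of the assay and not a number. Among these compounds, compound 1 also stands only on a limit, so no step between compound 1 and compound 3 can be read. The compounds shown leave open whether (3,4-dichlorophenyl)amino in place of 3-(trifluoromethyl)phenyl changes the lethal concentration at all.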